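A few compounds are considered here, and "the series" means these few. Any claim that something is new, unique, unknown or untested is made for them only; others in the source may bear on it.

Compound 1 `CCCS(=O)(=O)Nc1ccc(F)c(C(=O)c2n[nH]c3ncc(-c4cccc(Cl)c4)cc23)c1F`: 40%
Compound 2 `CCCS(=O)(=O)Nc1ccc(F)c(C(=O)c2n[nH]c3ncc(-c4ccccc4OC)cc23)c1F`: 1.9%
Compound 3 `CCCS(=O)(=O)Nc1ccc(F)c(C(=O)c2n[nH]c3ncc(-c4ccccc4N)cc23)c1F`: 23%

In an assay for binding affinity to dual specificity mitogen-activated protein kinase kinase 4 (Homo sapiens), read by KINOMEscan, tested at 100 nM (on this read-out higher numbers stand for a weaker effect at the one concentration tested and lower numbers for a stronger effect), compound 1 gives the highest of the three numbers, that is, the weakest effect: the step of a number 38.1 percentage points lower from compound 1 to compound 2 (beyond the scatter) is large and the step of a number 17 percentage points lower from compound 1 to compound 3 (beyond the scatter) is modest, both toward stronger binding. Compound 4 `CCCS(=O)(=O)Nc1ccc(F)c(C(=O)c2n[nH]c3ncc(-c4cc(Cl)cc(Cl)c4)cc23)c1F` differs from compound 1 by chloro in place of hydrogen on an aromatic carbon. Going by the values given here, no measured step bears on this change: the two steps from compound 1 exchange the whole 3-chlorophenyl group for a 2-substituted phenyl group, and the step of a number 21.1 percentage points higher from compound 2 to compound 3 (beyond the scatter) is an exchange of amino for methoxy, so none of them adds a second chloro. With nothing to go on, no step beyond the scatter is expected. The estimate for compound 4 is 40%, with a range from 15% to 70%. The expected step is no change at the digits printed from compound 1 to compound 4 (within the scatter).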

Compound 4, a percentage reported as activity, at one concentration (the size of the read-out at that concentration, not a potency): 73%
For compound 4 the middle estimate is 33 percentage points below the measured one, and the stated range ends below it.
By their numbers in this assay, from the lowest: compound 2; then compound 3; then compound 1; then compound 4.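

In this assay, a second chloro on the 3-chlorophenyl group gives a weaker effect (a number 33 percentage points higher from compound 1 to compound 4 (beyond the scatter)), so this place on the ring is sensitive to the addition of a single heavy atom. The 3,5-dichlorophenyl group also gives a weaker effect than either 2-substituted phenyl group (a number 50 percentage points higher from compound 3 to compound 4 (beyond the scatter); a number 71.1 percentage points higher from compound 2 to compound 4 (beyond the scatter)). Nothing given here explains these steps. On these data alone, it remains open whether a nitrile or a carboxylic acid in place of the second chloro would give a similarly weak effect.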